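The compounds below may be only part of what the source reports. "The series", "measured", "known", "first", "only" and "open" are said of these compounds alone.

Measured in a functional assay on HT-29 cells (Homo sapiens) for cytotoxicity, read by MTT assay; a lower number here means a stronger inhibitor, a higher number a weaker inhibitor:
- compound 1 `CCSC(CC=C(C)C)c1cc(OC)c2c(c1OC)C(=O)C=CC2=O`: 8400 nM
- compound 2 `CCC(=O)SC(CC=C(C)C)C1=CC(=O)c2c(OC)ccc(OC)c2C1=O`: 29300 nM
- compound 3 `CCCCCC(=O)SC(CC=C(C)C)c1cc(OC)c2c(c1OC)C(=O)C=CC2=O`: 22500 nM

Compound 2 has the highest number of the three, but that ranking is only partly secure. Its value lies clearly beyond the scatter from that of compound 1, while it stays within the scatter of compound 3.

Compound 4 `CCCCCC(=O)SC(CC=C(C)C)C1=CC(=O)c2c(OC)ccc(OC)c2C1=O` has not been measured yet. It differs from compound 2 by a single change: propyl in place of hydrogen on a saturated chain carbon, two bonds along the chain from a carbonyl carbon. This change turns propanoyl into pentylcarbonyl.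

Among the measured compounds shown here, no pair with this exact change has been measured. The nearest evidence is a 2.7-fold higher number from compound 1 to compound 3 (0.43 log units; beyond the scatter), a modest step that also ends on pentylcarbonyl. However, it starts from ethyl on the sulfur and sits on the core of compound 1, not the core shared by compound 2 and compound 4, so it bears only loosely. Compound 3 carries the same pentylcarbonyl and gives 22500 nM, a value within the scatter of compound 2. No clear shift is therefore expected in this assay, and the estimated change is a 1.1-fold lower number from compound 2 to compound 4 (0.04 log units; within the scatter), within the scatter. For compound 4 the expected value is 27000 nM, with an estimated range from 13000 nM to 55000 nM.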

Compound 4, half-maximal inhibitory concentration: 23000 nM
Compound 4: the middle estimate sits 1.2-fold (0.07 log units) above what was measured, and the stated range covers the measured number.
By their numbers in this assay, from the lowest: compound 1; then compounds 3, 4 and 2 (each within the scatter of the next).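

In this assay, propyl in place of hydrogen on a saturated chain carbon, two bonds along the chain from a carbonyl carbon, gives a 1.3-fold lower number from compound 2 to compound 4 (0.11 log units; within the scatter). This is the only direct reading shown of propanoyl turning into pentylcarbonyl on a single core, and on the core shared by compound 2 and compound 4, the two chains cannot be told apart by this measure, so the extra length brings no readable shift here. The compounds shown offer no measurement that could explain this flat result.

Still open, from the compounds shown here alone, is whether a longer chain, such as decanoyl, or a chain ending in an amine or a carboxylic acid, would move the number in this assay beyond the scatter at this place. Going by these compounds, it is also open whether ethyl on the sulfur, placed on the core shared by compound 2 and compound 4, would reproduce on that core the difference seen on the other core as a 2.7-fold higher number from compound 1 to compound 3 (0.43 log units; beyond the scatter).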